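The compounds below may be only part of what the source reports. "The series", "measured", "known", "first", "only" and "open" are said of these compounds alone.

Working notes on the series. All three measured compounds share one core and differ only in the group on an amide-type nitrogen in a ring. Compound 1 `COc1ccc(F)cc1N1C(=O)CSC1c1cccc(C(=O)NCCCCc2ccccc2)c1` carries 5-fluoro-2-methoxyphenyl there, and in a functional assay on HOS cells (Homo sapiens) for inhibition, read by CCK-8 assay, with a stated time of 72 h, tested at 1 uM (on this read-out higher numbers stand for more inhibition at the one concentration tested (going by the name of the read-out) and lower numbers for less inhibition), compound 1 gives 46%. Compound 2 `CCN1C(=O)CSC1c1cccc(C(=O)NCCCCc2ccccc2)c1` carries ethyl in the same place; in this assay compound 2 gives 6%. Compound 3 `COc1cccc(OC)c1N1C(=O)CSC1c1cccc(C(=O)NCCCCc2ccccc2)c1` carries 2,6-dimethoxyphenyl, and in this assay compound 3 gives 80%, the highest of the three numbers, compound 1 nearest and compound 2 furthest. The steps all lie beyond the scatter: a number 40 percentage points lower from compound 1 to compound 2 (beyond the scatter), a number 34 percentage points higher from compound 1 to compound 3 (beyond the scatter), and a number 74 percentage points higher from compound 2 to compound 3 (beyond the scatter).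

Compound 4 `O=C(NCCCCc1ccccc1)c1cccc(C2SCC(=O)N2c2ccccc2F)c1` is the next member; it differs from compound 3 in one place: 2-fluorophenyl in place of 2,6-dimethoxyphenyl on an amide-type nitrogen in a ring. Among the compounds with values here, the steps that bear on this are a number 74 percentage points higher from compound 2 to compound 3 (beyond the scatter) and a number 34 percentage points higher from compound 1 to compound 3 (beyond the scatter): an aryl group on this nitrogen sits far above ethyl, and the aryl with two methoxy groups sits well above the aryl with one methoxy and one fluorine. An aryl group with fluorine only and no methoxy has not been measured. Within the data shown here, a drop beyond the scatter is therefore expected, likely at least as large as the one from compound 3 to compound 1, since compound 1 at 46% still keeps one methoxy. For compound 4 the expected step is a number 45 percentage points lower from compound 3 to compound 4 (beyond the scatter). Compound 4 is estimated at 35%, in the range 10% to 62%.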

Compound 4, a percentage reported as inhibition, at one concentration (the size of the read-out at that concentration, not a potency): 83%
Compound 4: the middle estimate sits 48 percentage points below what was measured; measured number outside the range, above it.
By their numbers in this assay, from the lowest: compound 2; then compound 1; then compounds 3 and 4 (each within the scatter of the next).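

The methoxy groups of compound 3 are not required for a high number at this position: in this assay the change to 2-fluorophenyl gives a number 3 percentage points higher from compound 3 to compound 4 (within the scatter) and so no separation between the two aryl groups, even though the entering group has fewer heavy atoms and no hydrogen-bond acceptors. The reading that more methoxy on this aryl group gives more inhibition therefore fails on compound 4, while a number 37 percentage points higher from compound 1 to compound 4 (beyond the scatter) shows that 5-fluoro-2-methoxyphenyl, which carries both fluorine and methoxy, is the aryl group that goes against any simple rule that aryl groups here sit at one high level. The gain over the alkyl group holds for this fluorinated aryl as well, with a number 77 percentage points higher from compound 2 to compound 4 (beyond the scatter) for the change from ethyl, but no available measurement explains why these groups differ.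

Open, as far as these compounds go, is whether a plain phenyl, a pyridine ring or a benzyl group on this nitrogen would match 2-fluorophenyl or fall towards 5-fluoro-2-methoxyphenyl. Since the read-out covers one concentration only, it also leaves open how compound 3 and compound 4 compare in potency.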